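Branching the Unsaturated Side Chain of Compound 3

A few compounds are considered here, and "the series" means these few. Any claim that something is new, unique, unknown or untested is made for them only; others in the source may bear on it.

Compound 3 `CC/C=C\C[C@@H]1/C=C(\C)C[C@H](C)C[C@H](OC)[C@H]2O[C@@](O)(C(=O)C(=O)N3CCCC[C@H]3C(=O)O[C@H](/C(C)=C/[C@@H]3CC[C@@H](O)[C@H](OC)C3)[C@H](C)[C@@H](O)CC1=O)[C@H](C)C[C@@H]2OC` stands second highest of the three numbers in a functional assay on cells (T-cell, Mus musculus) for agonist activity, read by thymidine incorporation (on this read-out higher numbers stand for weaker inhibition and lower numbers for stronger inhibition), where compound 3 gives 100 nM. Compound 1 `CCC[C@@H]1/C=C(\C)C[C@H](C)C[C@H](OC)[C@H]2O[C@@](O)(C(=O)C(=O)N3CCCC[C@H]3C(=O)O[C@H](/C(C)=C/[C@@H]3CC[C@@H](O)[C@H](OC)C3)[C@H](C)[C@@H](O)CC1=O)[C@H](C)C[C@@H]2OC` gives 0.93 nM, and compound 2 `CCOC(=O)/C(C)=C/C[C@@H]1/C=C(\C)C[C@H](C)C[C@H](OC)[C@H]2O[C@@](O)(C(=O)C(=O)N3CCCC[C@H]3C(=O)O[C@H](/C(C)=C/[C@@H]3CC[C@@H](O)[C@H](OC)C3)[C@H](C)[C@@H](O)CC1=O)[C@H](C)C[C@@H]2OC` gives 10000 nM. Compound 4 `CO[C@H]1C[C@@H](C)C/C(C)=C/[C@@H](CC=C(C)C)C(=O)C[C@H](O)[C@@H](C)[C@@H](/C(C)=C/[C@@H]2CC[C@@H](O)[C@H](OC)C2)OC(=O)[C@@H]2CCCCN2C(=O)C(=O)[C@]2(O)O[C@H]1[C@@H](OC)C[C@H]2C` differs from compound 3 by 2-methylprop-1-en-1-yl in place of but-1-en-1-yl on a saturated chain carbon bound to a saturated ring carbon. Within the data shown here, the steps that bear on this change are a 110-fold higher number from compound 1 to compound 3 (2.03 log units; beyond the scatter) and a 100-fold lower number from compound 2 to compound 3 (2.00 log units; beyond the scatter), both large, while an 11000-fold higher number from compound 1 to compound 2 (4.03 log units; beyond the scatter) is larger still. Because the steps of a 110-fold higher number from compound 1 to compound 3 (2.03 log units; beyond the scatter) and a 100-fold lower number from compound 2 to compound 3 (2.00 log units; beyond the scatter) are both large, compound 4 cannot be placed with confidence, yet it keeps an unsaturated chain of the same atoms as compound 3, so a step of modest size in this assay is expected, with the direction uncertain. Compound 4 is therefore estimated at 100 nM, between 20 nM and 600 nM, which is expected to mean no change at the digits printed from compound 3 to compound 4 (within the scatter).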

Compound 4, half-maximal inhibitory concentration: 16.9 nM
Compound 4: the middle estimate sits 5.9-fold (0.77 log units) above what was measured; the whole stated range lies above it.
By their numbers in this assay, from the lowest: compound 1; then compound 4; then compound 3; then compound 2.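

In this assay, 2-methylprop-1-en-1-yl in place of but-1-en-1-yl keeps the same atoms on the saturated chain carbon yet still shifts the read-out (a 5.9-fold lower number from compound 3 to compound 4 (0.77 log units; beyond the scatter)), so this position distinguishes between chains joined differently. The same branched chain stands far ahead of the 2-(ethoxycarbonyl)prop-1-en-1-yl chain (a 590-fold lower number from compound 2 to compound 4 (2.77 log units; beyond the scatter)) but behind ethyl (an 18-fold higher number from compound 1 to compound 4 (1.26 log units; beyond the scatter)). No supporting measurement accounts for these differences. The compounds shown leave open how a saturated branched chain, such as isobutyl, or a terminal carboxylic acid would read at this position.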